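Aryl cyanoguanidine swap on a shared aortic relaxant core

The compounds below may be only part of what the source reports. "The series", "measured", "known", "first", "only" and "open" are said of these compounds alone.

Measured compounds:
compound 1, `CC1(C)Oc2ccc(C#N)cc2[C@@H](NC(=O)NCc2ccccc2)[C@@H]1O` — 5600 nM
compound 2, `CC1(C)Oc2ccc(C#N)cc2[C@@H](/N=C(\NC#N)Nc2ccc(C(F)(F)F)cc2)[C@@H]1O` — 8100 nM

Of the compounds shown here, two have been tested in a functional assay (aorta) with Rattus norvegicus as the target; a lower number here means a stronger inhibitor, a higher number a weaker inhibitor. Compound 1 carries a benzyl urea on the shared core and gives 5600 nM. Compound 2 carries an aryl cyanoguanidine on the same core and gives 8100 nM. Among the measured compounds shown here, the two numbers differ by less than the usual scatter, so compound 2 cannot be set apart from compound 1 in this assay; it stands level with the only other number available.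

Compound 3, `Cc1ccc(N/C(=N/[C@@H]2c3cc(C#N)ccc3OC(C)(C)[C@H]2O)NC#N)cc1C`, has not yet been measured. It differs from compound 2 in one place: 3,4-dimethylphenyl in place of 4-(trifluoromethyl)phenyl on an amine nitrogen. The cyanoguanidine and the shared core are unchanged.

For the measured compounds named here, no step between measured compounds exists that would show what this kind of exchange does in this assay, so the expectation rests on compound 2 alone. With one aryl group exchanged for another of similar size, the step from compound 2 to compound 3 is expected to stay within the scatter, a 1.2-fold lower number from compound 2 to compound 3 (0.06 log units; within the scatter), with no clear direction. Compound 3 is therefore estimated at 7000 nM, within a range of 2500 nM to 20000 nM.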

Compound 3, half-maximal inhibitory concentration: 5100 nM
Compound 3: the middle estimate sits 1.4-fold (0.14 log units) above what was measured; the measured number falls inside the stated range.
By their numbers in this assay, from the lowest: compounds 3, 1 and 2 (each within the scatter of the next).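

In this assay, placing 3,4-dimethylphenyl where 4-(trifluoromethyl)phenyl stood on the amine nitrogen gives a 1.6-fold lower number from compound 2 to compound 3 (0.20 log units; within the scatter) and is the only step shown at this position. It shows that an aryl group of carbon only can take the place of one carrying fluorine on this nitrogen, with the cyanoguanidine and the shared core unchanged, without a difference that can be told apart from repeat measurements. Nothing measured here accounts for this result.

Both aryl groups are six-membered aromatic rings of carbon, so the compounds shown leave open whether this position responds at all to a larger change, such as an amine or a carboxylic acid on the ring, or a longer chain or a simple alkyl group in place of the ring. They also leave open whether the same exchange would give a similar step with another group in place of the cyanoguanidine, such as the benzyl urea of compound 1, and whether the nitrile or the hydroxyl on the shared core contributes to these numbers.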